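The compounds below may be only part of what the source reports. "The series", "measured", "known", "first", "only" and "open" are said of these compounds alone.

Measured so far:
Compound 1, `O=C(Nc1ccccc1)Nc1nc(NC2CC2)cc(Sc2c[nH]c3ccccc23)n1`, in a functional assay on HepG2 cells (Homo sapiens) for inhibition, with a stated time of 72 h (a higher number here means a weaker inhibitor, a lower number a stronger inhibitor), gives 14300 nM.
Compound 2, `O=C(Nc1ccccc1)Nc1nc(Sc2c[nH]c3ccccc23)cc(N2CCCC2)n1`, in this assay gives 11400 nM.

Among the compounds with values here, compound 2 holds the lowest of the two numbers in this assay, but its nearest neighbour is compound 1, and the only step between them, a 1.3-fold lower number from compound 1 to compound 2 (0.10 log units; within the scatter), stays within the scatter, so the two cannot be told apart on these numbers.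

The next compound, compound 3, `O=C(Nc1ccccc1)Nc1nc(Nc2ccccc2)cc(Sc2c[nH]c3ccccc23)n1`, changes the same position once more: anilino in place of pyrrolidin-1-yl on an aromatic carbon. Within the data shown here, the one measured step bears on this position, since it also swapped the group there, and it produced no change beyond the scatter. Among the measured compounds shown here, that is the only guide; nothing measured tells how an anilino group behaves at this place. The expectation in this assay is therefore a step of a 1.3-fold lower number from compound 2 to compound 3 (0.10 log units; within the scatter), which amounts to no change beyond the scatter, with a wide range to allow for an unmeasured group. Compound 3 is expected to give about 9000 nM, estimated between 2500 nM and 30000 nM.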

Compound 3, half-maximal inhibitory concentration: 14400 nM
Compound 3: middle estimate off by 1.6-fold (0.20 log units), on the low side, within the range that was stated.
By their numbers in this assay, from the lowest: compounds 2, 1 and 3 (each within the scatter of the next).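

In this assay, this position on the shared core now carries three different groups, cyclopropylamino, pyrrolidin-1-yl and anilino, and none of the steps between them goes beyond the scatter. The new result extends that picture to an aromatic ring of carbon only: a 1.3-fold higher number from compound 2 to compound 3 (0.10 log units; within the scatter) replaces a non-aromatic ring joined through its nitrogen with anilino, while a 1.0-fold higher number from compound 1 to compound 3 (0.00 log units; within the scatter) exchanges cyclopropyl for phenyl on the nitrogen, so neither change separates the compounds on these numbers. No supporting measurement is available to explain why these compounds cannot be told apart.

The compounds shown leave open whether a group of another kind at this position, such as a carboxylic acid, a primary amine or a longer alkyl chain, or a substituent such as fluorine on the anilino ring, would give a step beyond the scatter. They also leave open whether changes to the (1H-indol-3-yl)sulfanyl group or the (phenylcarbamoyl)amino group would move the number in this assay more than changes at this position have.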